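The source may report more compounds than this note shows. Statements on the series, on what has been measured and on what is new or still open speak of the compounds shown alone.

In a functional assay on the whole organism for antagonist activity, with Mus musculus as the target (on this read-out lower numbers stand for an effect already at smaller amounts and higher numbers for an effect only at larger amounts of compound), compound 1 `Cc1cncn1CC#CCN1CCNC1=O` gives a real number, 21 mg/kg. On these data alone, compound 2 `CN1CCN(CC#CCn2ccnc2)C1=O` has only a limit of the assay, > 100 mg/kg, not a number, so its true position on the scale is unknown.

Compound 3 `Cc1cncn1CC#CCN1CCN(C)C1=O` changes compound 2 in one place: methyl in place of hydrogen on an aromatic carbon, (methyl in place of hydrogen on an aromatic carbon). This carbon lies on the five-membered aromatic ring, next to the ring nitrogen. Going by the values given here, no measured pair isolates this change, so the expectation rests on thin ground. Among the compounds with values here, the only guide is compound 1, which carries the same methyl and gives 21 mg/kg.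

A clear move toward smaller doses is therefore expected in this assay, with the estimated step of an at least 3.3-fold lower number from compound 2 to compound 3 (0.52 log units; beyond the scatter), although compound 3 could also stay at the limit. Compound 3 is estimated at 30 mg/kg, with an expected range from 8 mg/kg to 100 mg/kg.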

Compound 3, dose for half-maximal effect: 14 mg/kg
For compound 3 the middle estimate is 2.1-fold (0.33 log units) above the measured one; low and high end bracket the measured number.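

Methyl in place of hydrogen on the aromatic carbon now has a pair that isolates it in this assay, and this change gives an at least 7.1-fold lower number from compound 2 to compound 3 (0.85 log units; beyond the scatter). The true size of this step remains unknown because compound 2 has only a limit of the assay rather than a number: the limit of > 100 mg/kg in this assay, at which 1 of the 3 values shown sits.

The second new pair isolates methyl in place of hydrogen on the amide-type nitrogen in a ring, and it gives a 1.5-fold lower number from compound 1 to compound 3 (0.18 log units; within the scatter), so with the aromatic methyl present, this pair cannot be told apart on this read-out. The compounds shown leave open how an ethyl group or a chlorine atom on that aromatic carbon would read. They also leave open what a longer chain on the amide-type nitrogen would do.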